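This account rests on a few compounds, and the source may have more. Where it says the series, first, only, none or still open, it means among the compounds named here.

Measured compounds in a functional assay on PC-3 cells (Homo sapiens) for inhibition; on this read-out higher numbers stand for weaker inhibition of growth and lower numbers for stronger inhibition of growth:
compound 1 `Cc1cccc(NC(=O)COc2ccc(/C=C3\SC(=O)NC3=O)cc2)n1` – 58300 nM
compound 2 `O=C(COc1ccc(/C=C2\SC(=O)NC2=O)cc1)Nc1cccc([N+](=O)[O-])c1` – > 100000 nM, a limit of the assay
compound 3 `O=C(COc1ccc(/C=C2\SC(=O)NC2=O)cc1)Nc1ccccc1` – > 100000 nM, a limit of the assay

Compound 3 thus stands at the limit of this assay and carries no number of its own; compound 2 sits at the same limit (the limit of > 100000 nM in this assay, at which 2 of the 3 values shown sit), and compound 1 alone gives a measured value. The step of an at least 1.7-fold higher number from compound 1 to compound 3 (0.23 log units; that floor lies within the scatter) and the step of an at least 1.7-fold higher number from compound 1 to compound 2 (0.23 log units; that floor lies within the scatter) both end at that limit, and the step that the two limits leave unreadable from compound 2 to compound 3 runs between two limits. Compound 4 `O=C(COc1ccc(/C=C2\SC(=O)NC2=O)cc1)Nc1ccc(Br)cc1` differs from compound 3 by bromo in place of hydrogen on an aromatic carbon. For the measured compounds named here, none of the measured steps alters the phenyl ring of compound 3 itself; the three measured changes all concern what sits on the amide-type nitrogen, and two of the three end at the limit. With compound 3 itself at the limit, compound 4 is expected to stay close to it, a step of a number no higher from compound 3 to compound 4 (the limit leaves the size open) that is not expected to be read as beyond the scatter. The estimate for compound 4 in this assay is 100000 nM, within 40000 nM to 250000 nM.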

Compound 4, concentration for 50% growth inhibition: 86600 nM
Compound 4: the middle estimate sits 1.2-fold (0.06 log units) above what was measured, and the stated range covers the measured number.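

Bromo is the first change shown on the phenyl ring itself, and in this assay it gives a measured number rather than a limit, with an at least 1.1-fold lower number from compound 3 to compound 4 (0.06 log units; that floor lies within the scatter) and an at least 1.1-fold lower number from compound 2 to compound 4 (0.06 log units; that floor lies within the scatter). For the compounds shown here, both floors lie within the scatter, so the result shows no gain beyond it, only that compound 4 does not sit at the limit: the limit of > 100000 nM in this assay, at which 2 of the 4 values shown sit. 4-Bromophenyl and 6-methylpyridin-2-yl on the amide-type nitrogen are not separated, with a 1.5-fold higher number from compound 1 to compound 4 (0.17 log units; within the scatter).

From the compounds shown here alone, the true size of the bromo step stays open, since compound 3 has only a limit and no number of its own. Also open, going by these compounds, is whether chloro, methoxy or an amine at the same place would give a number clearly lower than that of compound 4.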